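Swapping methylsulfonyl for methylamino in a reductase inhibitor series

The source may report more compounds than this note shows. Statements on the series, on what has been measured and on what is new or still open speak of the compounds shown alone.

Compound 1 `Cc1nc(-c2ccc(F)cc2)c(-c2ccc(F)cc2)n1/C=C/[C@@H](O)C[C@@H](O)CC(=O)O`, compound 2 `Cc1cc(C)cc(-c2c(-c3ccc(F)cc3)nc(C(C)C)n2/C=C/[C@@H](O)C[C@@H](O)CC(=O)O)c1` and compound 3 `CC(C)c1nc(-c2cccc(S(C)(=O)=O)c2)c(-c2ccc(F)cc2)n1/C=C/[C@@H](O)C[C@@H](O)CC(=O)O` share one core and have been tested in an assay on isolated protein for inhibition of 3-hydroxy-3-methylglutaryl-coenzyme A reductase (Homo sapiens); on this read-out higher numbers stand for weaker inhibition and lower numbers for stronger inhibition. Compound 1 reaches only a limit of the assay, < 7 nM, so it yields no number. Compound 2 gives 7.25 nM. Compound 3 gives 8.7 nM, numerically the larger of the two numbers shown, yet within the usual scatter of the value of compound 2, so no real difference between them can be claimed. Compound 4 `CNc1cccc(-c2nc(C(C)C)n(/C=C/[C@@H](O)C[C@@H](O)CC(=O)O)c2-c2ccc(F)cc2)c1` has not been measured. It differs from compound 3 in one place: methylamino in place of methylsulfonyl on an aromatic carbon. Within the data shown here, no measured pair in this set shows that change, so there is no direct guide to its effect, and the near-equal values of compound 2 and compound 3 across quite different substituents offer no hint of a large shift. The step from compound 3 to compound 4 is therefore expected to be small, a 1.1-fold higher number from compound 3 to compound 4 (0.06 log units; within the scatter), not clearly beyond the scatter. Compound 4 is estimated at 10 nM, with a likely range from 4 nM to 28 nM.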

Compound 4, half-maximal inhibitory concentration: 8.52 nM
For compound 4 the middle estimate is 1.2-fold (0.07 log units) above the measured one, within the range that was stated.
By their numbers in this assay, from the lowest: compounds 2, 4 and 3 (each within the scatter of the next). At a limit, below all of these: compound 1.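

In this assay, among these compounds, methylamino in place of methylsulfonyl gives a 1.0-fold lower number from compound 3 to compound 4 (0.01 log units; within the scatter), the first direct reading of this swap at this position on the ring. The two groups are far from alike: methylamino has fewer heavy atoms and brings a hydrogen-bond donor that methylsulfonyl lacks, yet the step stays within the scatter, so this position accepts both groups with no measurable change. A stronger replacement could prove hard to read in this assay, because compound 1 already reaches a limit: the limit of < 7 nM in this assay, at which 1 of the 4 values shown sits.

Open, as far as these compounds go, is whether a carboxylic acid or a longer chain such as butylamino in the same place would read alike. Also open, from the compounds shown here alone, is whether any group is needed there at all, which a plain hydrogen on that ring carbon would test.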